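This account rests on a few compounds, and the source may have more. Where it says the series, first, only, none or still open, it means among the compounds named here.

Measured compounds in a functional assay on YAC-1 cells (Mus musculus); on this read-out higher numbers stand for larger maximal responses and lower numbers for smaller maximal responses:

Compound 1, `Nc1nc(O)c2c(n1)n(C1OC(CO)[C@@H](O)[C@H]1O)c(=O)n2Cc1ccc(Cl)c(Cl)c1`, gives 15%.
Compound 2, `C=CCn1c(=O)n([C@@H]2O[C@H](CO)[C@H]3OC(CCC)(CCC)O[C@H]32)c2nc(N)nc(O)c21`, gives 56%.
Compound 3, `Nc1nc(O)c2c(n1)n(C1OC(CO)[C@@H](O)[C@H]1O)c(=O)n2Cc1ccc(Cl)cc1`, gives 27%.

Compound 3 stands second highest of the three. Its nearest neighbour is compound 1, lower by a number 12 percentage points higher from compound 1 to compound 3 (beyond the scatter); compound 2 stands well above it. Compound 4, `N#Cc1cccc(Cn2c(=O)n(C3OC(CO)[C@@H](O)[C@H]3O)c3nc(N)nc(O)c32)c1`, arises from compound 3 through (3-cyanophenyl in place of 4-chlorophenyl on a saturated chain carbon bound to an aromatic nitrogen). Within the data shown here, only one measured step bears on this place, a number 12 percentage points higher from compound 1 to compound 3 (beyond the scatter), and it concerns a chloro group, not a nitrile, so it gives a direction only loosely. Among the measured compounds shown here, no measured compound carries a cyanophenyl group. A step near a number 3 percentage points higher from compound 3 to compound 4 (within the scatter) is therefore expected, with little change beyond the scatter. Compound 4 is estimated at 30%, within 15% to 50%.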

Compound 4, largest response reached (reported as maximal response), in percent of the reference or control that the assay uses: 11%
For compound 4 the middle estimate is 19 percentage points above the measured one; the measured number lies below the stated range.
By their numbers in this assay, from the lowest: compounds 4 and 1 (each within the scatter of the next); then compound 3; then compound 2.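

In this assay, the change from 4-chlorobenzyl to 3-cyanobenzyl gives a number 16 percentage points lower from compound 3 to compound 4 (beyond the scatter) and so shows that this place tolerates not every swap of the aromatic substituent. The change from the 3,4-dichlorophenyl group gives a number 4 percentage points lower from compound 1 to compound 4 (within the scatter) and so shows that two differently substituted rings can give similar responses here. No measurement at hand explains either step.

Compound 3 and compound 4 differ in both the group and its place on the ring, so those two changes cannot be separated. From the compounds shown here alone, how an amine or a carboxylic acid on that ring would behave also remains open.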